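Amino for hydrogen: from compound 3 to compound 4

A few compounds are considered here, and "the series" means these few. Any claim that something is new, unique, unknown or untested is made for them only; others in the source may bear on it.

Values in an ADME assay on L6 cells (Rattus norvegicus) for cytotoxicity, read by resazurin assay, with a stated time of 72 h; on this read-out lower numbers stand for stronger inhibition and higher numbers for weaker inhibition:
- compound 1 `OC(c1ccc(Cl)cc1)(c1cccnc1)c1cccc(F)c1`: 66000 nM
- compound 2 `OC(c1ccc(Cl)cc1)(c1ccc(Br)cc1)c1cccnc1`: 57000 nM
- compound 3 `OC(c1ccc(Cl)cc1)(c1cccnc1)c1cncs1`: > 100000 nM

Compound 3 gives > 100000 nM, which is a limit of the assay and not a number. Compound 4 `Nc1ncc(C(O)(c2ccc(Cl)cc2)c2cccnc2)s1` differs from it in one place: amino in place of hydrogen on an aromatic carbon. This is amino in place of hydrogen on an aromatic carbon, turning 1,3-thiazol-5-yl into 2-amino-1,3-thiazol-5-yl.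

Going by the values given here, no measured step adds an amino group, so the evidence is indirect. Among the compounds with values here, the steps that bear on it exchange whole groups on the shared core. The first is a 1.2-fold lower number from compound 1 to compound 2 (0.06 log units; within the scatter). The others are an at least 1.5-fold higher number from compound 1 to compound 3 (0.18 log units; that floor lies within the scatter) and an at least 1.7-fold higher number from compound 2 to compound 3 (0.24 log units; that floor lies within the scatter). Going by these compounds, both of these are floors, so the true size of each remains open.

In this assay, within the data shown here, no step clearly beyond the scatter is therefore expected, though a modest move to lower numbers is possible, toward compound 2 at 57000 nM. The estimated change is an at least 1.3-fold lower number from compound 3 to compound 4 (0.12 log units; that floor lies within the scatter). Compound 4 is expected at 75000 nM, with an estimated range of 30000 nM to 150000 nM.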

Compound 4, half-maximal inhibitory concentration: 56000 nM
Compound 4: the middle estimate sits 1.3-fold (0.13 log units) above what was measured; the range from low to high includes it.
By their numbers in this assay, from the lowest: compounds 4, 2 and 1 (each within the scatter of the next). At a limit, above all of these: compound 3.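

In this assay, amino in place of hydrogen on this aromatic carbon, next to the ring nitrogen and next to the ring sulfur, gives an at least 1.7-fold lower number from compound 3 to compound 4 (0.25 log units; that floor lies within the scatter), so the change yields a measured number where the 1,3-thiazol-5-yl compound gave none. That step remains a floor because compound 3 stands at a limit of the assay and not at a number: the limit of > 100000 nM in this assay, at which 1 of the 4 values shown sits. The 2-amino-1,3-thiazol-5-yl group also reads level with the two phenyl groups on the shared core, with a 1.0-fold lower number from compound 2 to compound 4 (0.01 log units; within the scatter) and a 1.2-fold lower number from compound 1 to compound 4 (0.07 log units; within the scatter).

The compounds shown leave open the true size of the step from hydrogen to amino. They also leave open whether a methylamino group, an acetamido group or a methyl group on this carbon would read like amino in this assay.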